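Lengthening the chain on compound 3 with a chlorine

A few compounds are considered here, and "the series" means these few. Any claim that something is new, unique, unknown or untested is made for them only; others in the source may bear on it.

Compound 1, `CC(C)C(=O)Nc1ccc(S(=O)(=O)Oc2ccccc2I)cc1`, gives 8100 nM in a functional assay on MCF7 cells (Homo sapiens) for antiproliferative activity, read by sulforhodamine B assay, with a stated time of 48 h; a higher number here means a weaker inhibitor, a lower number a stronger inhibitor.
Compound 2, `O=C(CCCl)Nc1ccc(S(=O)(=O)Oc2ccccc2I)cc1`, gives 8900 nM in this assay.
Compound 3, `CCNC(=O)Nc1ccc(S(=O)(=O)Oc2ccccc2I)cc1`, gives 1100 nM in this assay.

Among these three, compound 3 has the lowest number, and since both a 7.4-fold lower number from compound 1 to compound 3 (0.87 log units; beyond the scatter) and an 8.1-fold lower number from compound 2 to compound 3 (0.91 log units; beyond the scatter) lie beyond the scatter, compound 3 is the strongest inhibitor of the three in this assay. Compound 4, `O=C(NCCCCl)Nc1ccc(S(=O)(=O)Oc2ccccc2I)cc1`, has not yet been measured. It differs from compound 3 by chloromethyl in place of hydrogen on a saturated chain carbon, two bonds along the chain from an amide-type nitrogen. The measured step that bears most on this change is a 1.1-fold higher number from compound 1 to compound 2 (0.04 log units; within the scatter), where a chlorine-bearing chain took the place of a branched group on the carbonyl carbon and the number stayed within the scatter. The other two steps concern the ethylamino group itself, which compound 4 keeps and only extends. Going by the values given here, on this basis no step beyond the scatter is expected in this assay, although only one relevant precedent exists. For compound 4 the estimated value is 1300 nM, expected to fall between 500 nM and 3500 nM. This estimate corresponds to an expected step of a 1.2-fold higher number from compound 3 to compound 4 (0.07 log units; within the scatter).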

Compound 4, half-maximal inhibitory concentration: 7600 nM
Beside the measured number, compound 4's estimate is 5.8-fold (0.77 log units) below it; measured number above the stated range.
By their numbers in this assay, from the lowest: compound 3; then compounds 4, 1 and 2 (each within the scatter of the next).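

In this assay, chloromethyl in place of hydrogen on a saturated chain carbon, two bonds along the chain from an amide-type nitrogen, gives a 6.9-fold higher number from compound 3 to compound 4 (0.84 log units; beyond the scatter), so this position does not tolerate the change as the earlier chlorine-bearing step on the carbonyl carbon might have suggested. The standing that ethylamino held over isopropyl and 2-chloroethyl does not carry over to (3-chloropropyl)amino, as a 1.2-fold lower number from compound 2 to compound 4 (0.07 log units; within the scatter) and a 1.1-fold lower number from compound 1 to compound 4 (0.03 log units; within the scatter) both lie within the scatter. The amide-type nitrogen on the carbonyl carbon is therefore not enough on its own to give the lower number, and among these four compounds only compound 3 stands apart, with compound 4 going against any reading that credits that nitrogen alone.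

As far as these compounds go, it remains open whether the chlorine or the longer chain carries the step: a propylamino group would separate the two, and a 2-chloroethylamino group would show how much chain the position accepts. No measurement offered here accounts for the step.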